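The source may hold more compounds than are shown below. What is called first, only, known or untested is meant among the compounds shown, and "the series" means these compounds.

Measured so far:
compound 1 `CCOC(=O)C1=CCCCC1S(=O)(=O)Cc1ccc(F)cc1Cl`: 10 nM; 10000 nM; 5.7 nM (3 entries)
compound 2 `COC(=O)C1=CCCCC1S(=O)(=O)Cc1ccc(F)cc1Cl`: 99 nM

Within the data shown here, in a functional assay on RAW264.7 cells (Mus musculus), read by fluorescence (on this read-out higher numbers stand for weaker inhibition and lower numbers for stronger inhibition), compound 2 gives 99 nM, the only number reported for it; a further entry carries no single number. Compound 1 shows (the several entries of compound 1 in this assay, 10 nM; 10000 nM; 5.7 nM (3 entries)), a set that spreads widely. Compound 3 `CCCOC(=O)C1=CCCCC1S(=O)(=O)Cc1ccc(F)cc1Cl` has not been measured in this assay. It differs from compound 2 by ethyl in place of hydrogen on a saturated chain carbon bound to an oxygen next to a carbonyl group. Among the measured compounds shown here, no measured step covers this change. The expected step of a 5.0-fold lower number from compound 2 to compound 3 (0.69 log units; beyond the scatter) points toward stronger inhibition, with wide uncertainty. Compound 3 is expected to give 20 nM, within a range of 4 nM to 150 nM.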

Compound 3, half-maximal inhibitory concentration: 14 nM
Beside the measured number, compound 3's estimate is 1.4-fold (0.15 log units) above it; low and high end bracket the measured number.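

In this assay, going from methoxycarbonyl to propoxycarbonyl gives a 7.1-fold lower number from compound 2 to compound 3 (0.85 log units; beyond the scatter), so at this place on the shared core the longer chain goes with stronger inhibition. Among these compounds, this is the only step here that can be read. Compound 1 carries its change at the same place, but steps to it cannot be read, since its entries spread too widely: the several entries of compound 1 in this assay, 10 nM; 10000 nM; 5.7 nM (3 entries). The compounds shown leave open how a butoxycarbonyl group, a branched chain or a free carboxylic acid at this place would read out.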